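A Smaller Side Group on the Retinoid Conjugate

The compounds below may be only part of what the source reports. "The series", "measured", "known", "first", "only" and "open" are said of these compounds alone.

Measured so far:
Compound 1 `Nc1ccccc1NC(=O)c1ccc(NCC(=O)OCc2cccnc2)cc1`: 9 nM
Compound 2 `CC1=C(/C=C/C(C)=C/C=C/C(C)=C/C(=O)Oc2ccc(COC(=O)Nc3ccccc3NC(=O)c3ccc(CNC(=O)OCc4cccnc4)cc3)cc2)C(C)(C)CCC1`: 170 nM

Both compounds were tested in a functional assay on MDA-MB-231 cells (Homo sapiens) for inhibition, read by MTT assay, with a stated time of 5 days; a higher number here means a weaker inhibitor of growth, a lower number a stronger inhibitor of growth. Compound 1 gives 9 nM, while compound 2 gives 170 nM. Of the two numbers, compound 2 stands at the higher one, and its distance from compound 1 lies beyond the usual scatter, so compound 2 is the weaker growth inhibitor of the pair. The two structures differ in many places at once, so no single cause can be read from this gap.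

Compound 3 `CC(=O)Nc1ccc(C(=O)Nc2ccccc2NC(=O)OCc2ccc(OC(=O)/C=C(C)/C=C/C=C(C)/C=C/C3=C(C)CCCC3(C)C)cc2)cc1` is not yet measured. It keeps the long retinoid chain, the ester and the carbamate of compound 2 and changes only one position on the inner ring: acetamido in place of ((((pyridin-3-yl)methoxy)carbonyl)amino)methyl on an aromatic carbon The group that leaves is the larger of the two; the one that enters is small and sits para to a large group.

Among the compounds with values here, no measured pair shows what this kind of swap does in this assay. With the bulk of compound 2 untouched, the step of a 1.1-fold lower number from compound 2 to compound 3 (0.05 log units; within the scatter) is expected to stay within the scatter, with no clear direction. Compound 3 is therefore estimated at 150 nM, within a range of 50 nM to 500 nM.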

Compound 3, concentration for 50% growth inhibition: 20 nM
Beside the measured number, compound 3's estimate is 7.5-fold (0.88 log units) above it, outside the stated range (below it).
By their numbers in this assay, from the lowest: compound 1; then compound 3; then compound 2.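

In this assay, putting acetamido in place of ((((pyridin-3-yl)methoxy)carbonyl)amino)methyl gives an 8.5-fold lower number from compound 2 to compound 3 (0.93 log units; beyond the scatter), so this place on an aromatic carbon, para to a large group, has a clear bearing on growth inhibition. The retinoid chain, the ester and the carbamate are the same in both compounds, so the step belongs to this single change, and it shows that a compound carrying all three can still give a much lower number when the group here is acetamido rather than the larger ((((pyridin-3-yl)methoxy)carbonyl)amino)methyl. No measurement of any underlying property comes with this pair, so the data offer no explanation for the step.

Within the data shown here, with only one such pair, the lower number cannot be assigned to the smaller size of the group, the removal of the pyridine ring or some feature of acetamido itself. Going by these compounds, it also remains open how an amine, a carboxylic acid or a longer acyl chain at this place would compare, and whether the same swap would give a similar step on a compound without the retinoid chain.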